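The source may report more compounds than this note shows. Statements on the series, on what has been measured and on what is new or still open speak of the compounds shown alone.

Of the compounds shown here, two built on the shared core have been tested in a functional assay on MCF7 cells (Homo sapiens) for cytotoxicity, read by MTT assay, with a stated time of 24 h; a higher number here means a weaker inhibitor, a lower number a stronger inhibitor. Compound 1 `COc1ccc(-c2nnc(N3CCN(C(=O)CN4CCN(c5ccccc5OC)CC4)CC3)nc2-c2ccc(OC)cc2)cc1` returns only a limit there, > 821000 nM. Compound 2 `COc1ccc(-c2nnc(N3CCN(C(=O)CN4CCN(c5ccccc5Cl)CC4)CC3)nc2-c2ccc(OC)cc2)cc1` also returns only a limit, > 814000 nM. For the measured compounds named here, the one measured step, a step that the two limits leave unreadable from compound 1 to compound 2, is therefore of unknown size, and the two values that exist in this assay are both limits (the limit of > 814000 nM in this assay, at which 1 of the 2 values shown sits, (the limit of > 821000 nM in this assay, at which 1 of the 2 values shown sits)). Compound 2 thus stands at a limit with no number of its own, and nothing ranks it against compound 1.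

Compound 3 `COc1ccc(-c2nnc(N3CCN(C(=O)CN4CCN(c5cccc(OC)c5)CC4)CC3)nc2-c2ccc(OC)cc2)cc1` differs from compound 2 by 3-methoxyphenyl in place of 2-chlorophenyl on an amine nitrogen in a ring. Going by the values given here, no measured step bears directly on this exchange; the single step available, from compound 1 to compound 2, cannot be read between its two limits, so it supplies no size and no direction. With nothing beyond the scatter to point to, no change in this assay is expected in either direction. Compound 3 is therefore expected also to sit at a limit, estimated at 900000 nM with a range of 300000 nM to 3000000 nM. The expected step that the limit leaves unreadable from compound 2 to compound 3 is accordingly one within the scatter.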

Compound 3, half-maximal inhibitory concentration: > 821000 nM
Compound 3 ended at the assay's limit (the forecaster's own chance of this, stated with the estimate: 85%); the middle value lies beyond the limit too.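

Compound 3, like compound 1 and compound 2, gives only a limit in this assay, so no step among these three compounds can be read: the limit of > 821000 nM in this assay, at which 2 of the 3 values shown sit.

The compounds shown leave open whether any of the three phenyl groups on the ring amine nitrogen differs from the others, since none has a number of its own in this assay.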